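A Fluorine on the Phenyl Arm of Compound 2

The source may hold more compounds than are shown below. What is called first, only, known or untested is meant among the compounds shown, and "the series" means these compounds.

Of the compounds shown here, three sharing one core have been measured in a functional assay on PC-3 cells (Homo sapiens) for cytotoxicity, read by MTT assay, with a stated time of 72 h; a higher number here means a weaker inhibitor, a lower number a stronger inhibitor. Compound 1 `O=C(Nc1nc2ccc(F)cc2s1)c1cn(-c2ccccc2)nc1-c1ccccc1` gives 3250 nM, compound 2 `O=C(Nc1nc2ccc(Cl)cc2s1)c1cn(-c2ccccc2)nc1-c1ccccc1` gives 3690 nM, and compound 3 `COc1ccc2nc(NC(=O)c3cn(-c4ccccc4)nc3-c3ccccc3)sc2c1` gives 17500 nM. Compound 2 thus holds the second highest of the three numbers: its nearest neighbour is compound 1, with a 1.1-fold higher number from compound 1 to compound 2 (0.06 log units; within the scatter), while compound 3 lies furthest away, with a 4.7-fold higher number from compound 2 to compound 3 (0.68 log units; beyond the scatter). The only modest shifts seen so far come from the methoxy group, as in a 5.4-fold higher number from compound 1 to compound 3 (0.73 log units; beyond the scatter).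

Compound 4 `O=C(Nc1nc2ccc(Cl)cc2s1)c1cn(-c2ccccc2)nc1-c1ccc(F)cc1` is not yet measured. It differs from compound 2 by fluoro in place of hydrogen on an aromatic carbon. Every measured step in this set changes the group on the other aromatic ring of the core, so none of them bears directly on a change at this phenyl group; what they do show is that swapping one halogen for another, as from compound 1 to compound 2, moved the number only within the scatter. For compound 4 an expected step of about a 1.1-fold lower number from compound 2 to compound 4 (0.02 log units; within the scatter) is estimated, which would mean no change beyond the scatter. The estimate for compound 4 in this assay is therefore 3500 nM, with a range from 1500 nM to 8500 nM.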

Compound 4, half-maximal inhibitory concentration: 3170 nM
Beside the measured number, compound 4's estimate is 1.1-fold (0.04 log units) above it; the range from low to high includes it.
By their numbers in this assay, from the lowest: compounds 4, 1 and 2 (each within the scatter of the next); then compound 3.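

Compound 4 is the only compound shown with a change at this phenyl group: in this assay, fluoro in place of hydrogen, para to a large group, gives a 1.2-fold lower number from compound 2 to compound 4 (0.07 log units; within the scatter) and so stays within the scatter. The other steps all concern the group on the other aromatic ring of the core, where methoxy stands beyond the scatter from both fluoro and chloro, so they said nothing about this phenyl group. This step shows that, with chloro held on the other ring, phenyl and 4-fluorophenyl cannot be told apart in this assay, although a single small substituent at one place is all it covers. No measurement is available that would explain this result.

On these data alone, whether an amine, a carboxylic acid or a longer chain at this same place would also stay within the scatter of compound 2 remains open. Also open, as far as these compounds go, is whether the fluoro step would read the same with fluoro or methoxy on the other ring in place of chloro.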